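Sulfoxide amide series: cytotoxicity notes toward compound 4

The compounds below may be only part of what the source reports. "The series", "measured", "known", "first", "only" and "open" are said of these compounds alone.

Measured compounds in an ADME assay on MT4 cells (Homo sapiens) for cytotoxicity, read by MTT assay, with a stated time of 5 days; on this read-out lower numbers stand for higher toxicity in this test and higher numbers for lower toxicity in this test:
- compound 1, `COc1cc2nc(SCC(=O)Nc3ccc(C(F)(F)F)cc3)nc(Nc3c(C)cc(/C=C/C#N)cc3C)c2cc1OC`: > 211000 nM
- compound 2, `COc1cc2nc(SCC(=O)Nc3ccc(C)cc3)nc(Nc3c(Cl)cc(/C=C/C#N)cc3Cl)c2cc1OC`: 2540 nM
- compound 3, `COc1cc2nc([S+]([O-])CC(=O)Nc3cccc(Cl)c3)nc(Nc3c(Cl)cc(/C=C/C#N)cc3Cl)c2cc1OC`: 68900 nM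

Compound 1 sits at a limit of the test, (the limit of > 211000 nM in this assay, at which 1 of the 3 values shown sits), and gives no number. Of the two compounds with a number, compound 3 has the higher one; compound 2 lies well below it, and the gap between compound 2 and compound 3 is beyond the usual scatter. Compound 2 and compound 3 differ in more than one place, so no single step can be read from them.

The next compound, compound 4, `COc1cc2nc([S+]([O-])CC(=O)Nc3ccc(C)cc3)nc(Nc3c(Cl)cc(/C=C/C#N)cc3Cl)c2cc1OC`, keeps the sulfoxide of compound 3 and changes only the amide end: 4-methylphenyl in place of 3-chlorophenyl on an amide-type nitrogen. The 4-methylphenyl group is already present in compound 2, but there it sits on the thioether, so the two cannot be compared directly with compound 3 or compound 4.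

The expected step from compound 3 to compound 4 in this assay is a modest move toward a lower number, a 1.7-fold lower number from compound 3 to compound 4 (0.24 log units; within the scatter), though one that may fall within the scatter. The estimate for compound 4 is 40000 nM, with a range from 8000 nM to 200000 nM.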

Compound 4, half-maximal cytotoxic concentration: 32200 nM
Compound 4: the middle estimate sits 1.2-fold (0.09 log units) above what was measured; the measured number falls inside the stated range.
By their numbers in this assay, from the lowest: compound 2; then compound 4; then compound 3. At a limit, above all of these: compound 1.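

Among these compounds, with the sulfoxide held fixed, the amide end gives the first readable single-place step: the number falls by a 2.1-fold lower number from compound 3 to compound 4 (0.33 log units; beyond the scatter) in this assay when 4-methylphenyl replaces 3-chlorophenyl on the amide-type nitrogen. The amide-end aryl group therefore registers in this read-out, although the step is only modest and compound 4 stays on the same side of the series as compound 3 in the order of numbers. Both groups are six-membered aromatic rings of carbon only, but the exchange alters both the substituent and its printed ring position, so this one step cannot separate the two changes, and no measurement at hand bears on its cause.

On these data alone, it remains open how 3-methylphenyl or 4-chlorophenyl would read at the same place, and so which part of the exchange goes with the step. Also open, as far as these compounds go, are whether the same exchange gives a step of similar size with the thioether in place of the sulfoxide, and how an aminophenyl or carboxyphenyl group would read at the amide end.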